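A few compounds are considered here, and "the series" means these few. Any claim that something is new, unique, unknown or untested is made for them only; others in the source may bear on it.

Of the compounds shown here, three have been measured in an assay on HEK293 cells for positive allosteric modulation of metabotropic glutamate receptor 2 (Rattus norvegicus), read by thallium flux, with a stated time of 2.5 min; on this read-out lower numbers stand for smaller maximal responses and higher numbers for larger maximal responses. Compound 1, `Cc1c(OCCCCOCOc2ccc(C(=O)O)cc2)ccc(C(=O)CC2CCCC2)c1O`, gives 95.4% in this assay. Compound 2, `Cc1c(OCCCCOc2cccc(C(=O)O)c2)ccc(C(=O)CC2CCCC2)c1O`, gives 80.6%. Among the measured compounds shown here, the one measured step, a number 14.8 percentage points lower from compound 1 to compound 2 (beyond the scatter), concerns the 3-carboxyphenyl in place of the (4-carboxyphenoxy)methyl and is unrelated to the change examined here. Compound 3, `Cc1ccc(C(=O)O)cc1OCCCCOc1ccc(C(=O)CC(C)C)c(O)c1C`, gives 76.9%, the lowest of the three numbers: compound 2 stands within the scatter of it, while compound 1 lies beyond the scatter above it.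

Compound 4, `Cc1ccc(C(=O)O)cc1OCCCCOc1ccc(C(=O)CC2CCCC2)c(O)c1C`, is compound 3 with one change: cyclopentyl in place of isopropyl on a saturated chain carbon bound to a carbonyl carbon. For the measured compounds named here, no measured step bears on this change. Going by the values given here, compound 1 and compound 2 both carry the cyclopentyl that enters here, and compound 2 stands within the scatter of compound 3 although the two differ in more than one place, so no step between them is defined. With nothing in the data pointing to a large shift, compound 4 is expected to land close to compound 3, with a step of a number 5.1 percentage points higher from compound 3 to compound 4 (within the scatter) that is not expected to exceed the scatter. The value of compound 4 in this assay is therefore estimated at 82%, with a range from 70% to 94%.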

Compound 4, largest response reached (reported as percent of maximum), in percent of the reference or control that the assay uses: 67.5%
Beside the measured number, compound 4's estimate is 14.5 percentage points above it, outside the stated range (below it).
By their numbers in this assay, from the lowest: compounds 4, 3 and 2 (each within the scatter of the next, the first and the last beyond it); then compound 1.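

The first step read at this position, a saturated chain carbon bound to a carbonyl carbon, shows that in this assay cyclopentyl in place of isopropyl, with its five-membered ring of carbon, gives a result within the scatter (a number 9.4 percentage points lower from compound 3 to compound 4 (within the scatter)). With cyclopentyl held in place, changes elsewhere give steps beyond the scatter: methyl in place of hydrogen on an aromatic carbon (a number 13.1 percentage points lower from compound 2 to compound 4 (beyond the scatter)) and 5-carboxy-2-methylphenyl in place of (4-carboxyphenoxy)methyl on an oxygen on a saturated carbon (a number 27.9 percentage points lower from compound 1 to compound 4 (beyond the scatter)), so among these compounds the isopropyl-to-cyclopentyl change is the only single change whose step stays within the scatter. Nothing available explains any of these steps.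

The compounds shown leave open whether a longer chain, a phenyl ring or a chain bearing an amine at this position would also stay within the scatter of compound 3 in this assay. They also leave open whether isopropyl and cyclopentyl would read alike on the side chain of compound 1, since this change has been read on the side chain of compound 3 alone.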